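The source may hold more compounds than are shown below. What is called first, only, known or untested is meant among the compounds shown, and "the series" means these compounds.

Measured in a functional assay on DU-145 cells (Homo sapiens) for inhibition, read by trypan blue exclusion, with a stated time of 96 h; on this read-out higher numbers stand for weaker inhibition of growth and lower numbers for stronger inhibition of growth:
- compound 1 `O=C(/C(=C\c1ccc([N+](=O)[O-])c(O)c1)SCc1ccc(Br)cc1)c1ccc([N+](=O)[O-])c(Cl)c1`: 1000 nM
- compound 2 `COc1ccc(/C=C(\C(=O)c2ccc(Cl)cc2)S(=O)(=O)Cc2ccccc2Cl)cc1`: 50000 nM

Of these two compounds, compound 1 has the lower number and so the stronger inhibition of growth. The gap between it and compound 2 lies beyond the usual scatter of repeated measurements. Within the data shown here, with only two values, however, this says little about which parts of either structure matter.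

The next compound to be tested is compound 3 `O=C(/C(=C\c1ccc([N+](=O)[O-])c(O)c1)SCc1ccc(Br)cc1)C1CCNC1`. It keeps the core of compound 1 but carries pyrrolidin-3-yl in place of 3-chloro-4-nitrophenyl on a carbonyl carbon. An aromatic ring thus gives way to a smaller non-aromatic one. Among the measured compounds shown here, no measured pair here shows what such a swap does, so any expectation is uncertain and the range must be wide.

The expected change in this assay is a modest one, a 3.0-fold higher number from compound 1 to compound 3 (0.48 log units; beyond the scatter), toward a higher number and weaker inhibition of growth. For compound 3 the estimated value is 3000 nM, with an expected range from 700 nM to 15000 nM.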

Compound 3, concentration for 50% growth inhibition: > 100000 nM
Compound 3 gave a limit, no number (the forecaster's own chance of this, stated with the estimate: 10%); at least 33-fold (1.52 log units) between middle value and limit.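

In this assay, what sits on this carbonyl carbon proves decisive: replacing 3-chloro-4-nitrophenyl with pyrrolidin-3-yl gives an at least 100-fold higher number from compound 1 to compound 3 (2.00 log units; beyond the scatter), a large step well beyond the scatter of repeated measurements. As far as these compounds go, the result for compound 3 is a limit of the assay and not a number, so this step gives only the smallest possible size of the change, and its true size remains unknown: the limit of > 100000 nM in this assay, at which 1 of the 3 values shown sits. Compound 3 keeps the rest of compound 1, so that shared part is not enough to give the growth inhibition seen with compound 1, and this position does not accept every ring.

The swap changes several things at once: an aromatic ring gives way to a non-aromatic one, the group has fewer heavy atoms, the chlorine and nitro group are lost, and a ring nitrogen with a hydrogen-bond donor enters, so the compounds shown cannot say which of these differences counts. A plain phenyl ring would test the need for the chlorine and nitro group, while a cyclopentyl ring would test the effect of the ring nitrogen.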